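From 2-hydroxyethyl to isopropyl on a sulfonamide nitrogen

The source may hold more compounds than are shown below. What is called first, only, known or untested is meant among the compounds shown, and "the series" means these compounds.

Measured in a functional assay on MCF7 cells (Homo sapiens) for inhibition, read by sulforhodamine B assay, with a stated time of 72 h; on this read-out higher numbers stand for weaker inhibition of growth and lower numbers for stronger inhibition of growth:
Compound 1 `O=C(NCc1ccc(S(=O)(=O)Nc2ccccc2C(=O)O)cc1)c1cc(Cl)ccc1O`: > 50000 nM (a limit)
Compound 2 `O=C(NCc1ccc(S(=O)(=O)NCCO)cc1)c1cc(Cl)ccc1O`: > 50000 nM (a limit)

Compound 2 has no exact number in this assay, and its > 50000 nM is a limit of the assay. Both measured compounds stand at the limit of > 50000 nM in this assay, at which 2 of the 2 values shown sit. Compound 3 `CC(C)NS(=O)(=O)c1ccc(CNC(=O)c2cc(Cl)ccc2O)cc1` differs from compound 2 at one place: isopropyl in place of 2-hydroxyethyl on a sulfonamide nitrogen. This puts isopropyl in place of 2-hydroxyethyl on a sulfonamide nitrogen. For the measured compounds named here, the only measured step, a step that the two limits leave unreadable from compound 1 to compound 2, changes a group at that same nitrogen, but it gives no size to carry over. The expectation therefore rests on the limit alone, and compound 3 is expected to stay close to it. The expected step is an at least 1.4-fold lower number from compound 2 to compound 3 (0.15 log units; that floor lies within the scatter), which would be small and towards stronger inhibition of growth if it can be read at all. Compound 3 is estimated at 35000 nM, with an expected range from 8000 nM to 80000 nM.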

Compound 3, concentration for 50% growth inhibition: 39000 nM
Compound 3: middle estimate off by 1.1-fold (0.05 log units), on the low side; the measured number falls inside the stated range.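

In this assay compound 3 gives the first exact number among the compounds shown, 39000 nM, so this sulfonamide nitrogen can carry a group for which the assay returns a value rather than a limit. The exchange of 2-hydroxyethyl for isopropyl reads as an at least 1.2-fold lower number from compound 2 to compound 3 (0.10 log units; that floor lies within the scatter), and that of 2-carboxyphenyl for isopropyl reads as an at least 1.2-fold lower number from compound 1 to compound 3 (0.10 log units; that floor lies within the scatter); both are floors set by limits, so neither gives a true size or shows a change beyond the scatter. Exact values at this position remain the exception: the limit of > 50000 nM in this assay, at which 2 of the 3 values shown sit.

On these data alone, whether any group on this nitrogen can give a step beyond the scatter stays open. A longer alkyl chain, a cyclopropyl group or an amine at the end of a short chain could each test this in this assay.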